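Taking the Hexyl Chain off Compound 2

The source may report more compounds than this note shows. Statements on the series, on what has been measured and on what is new or still open speak of the compounds shown alone.

In a functional assay on SW480 cells (Homo sapiens) for antiproliferative activity, read by MTT assay, with a stated time of 48 h (on this read-out higher numbers stand for weaker inhibition and lower numbers for stronger inhibition), compound 1 `CCCCC(CCO)n1cnc2c(Cl)nc(F)nc21` gives 13200 nM and compound 2 `CCCCCCC(CCO)n1cnc2c(Cl)nc(F)nc21` gives 12900 nM. These two values lie within the scatter of each other, so compound 2 stands level with compound 1. Compound 3 `OCCCn1cnc2c(Cl)nc(F)nc21` differs from compound 2 by hydrogen in place of hexyl on a saturated chain carbon bound to an aromatic nitrogen and a saturated chain carbon, with hydrogen in place of hexyl on a saturated chain carbon bound to an aromatic nitrogen and a saturated chain carbon. Going by the values given here, only one measured step bears on this change: a 1.0-fold lower number from compound 1 to compound 2 (0.01 log units; within the scatter), where ethyl takes the place of hydrogen on the chain. That step involves ethyl rather than hexyl, so it offers only loose guidance. In this assay, no step beyond the scatter is expected, with a slight lean towards a higher number. The expected step is a 1.6-fold higher number from compound 2 to compound 3 (0.19 log units; within the scatter). For compound 3 the estimated value is 20000 nM, within an expected range of 8000 nM to 50000 nM.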

Compound 3, half-maximal inhibitory concentration: 29700 nM
Estimate against measurement, compound 3: 1.5-fold (0.17 log units) below; low and high end bracket the measured number.
By their numbers in this assay, from the lowest: compounds 2 and 1 (each within the scatter of the next); then compound 3.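

In this assay, going by these compounds alone, this saturated chain carbon responds for the first time: hydrogen in place of hexyl gives a 2.3-fold higher number from compound 2 to compound 3 (0.36 log units; beyond the scatter) and hydrogen in place of butyl gives a 2.3-fold higher number from compound 1 to compound 3 (0.35 log units; beyond the scatter), so compound 3 is the weakest of the three. The earlier pair showed only that going from butyl to hexyl leaves the number within the scatter, as a 1.0-fold lower number from compound 1 to compound 2 (0.01 log units; within the scatter) records. Taken together, the three compounds show that having a butyl or hexyl chain on this carbon gives a modestly lower number than having hydrogen there, though no data shown here explain why. As far as these compounds go, it remains open whether a short chain such as methyl or ethyl would already give the lower number, and whether a longer chain such as octyl would move it further. From the compounds shown here alone, how an amine or a carboxylic acid on this carbon would compare also remains open.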